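Methoxy on the urea phenyl of compound 2

This account rests on a few compounds, and the source may have more. Where it says the series, first, only, none or still open, it means among the compounds named here.

Compound 2 `O=C(Nc1ccccc1)Nc1nc(Sc2c[nH]c3ccccc23)cc(N2CCN(Cc3ccccc3)CC2)n1` holds the lowest number of the three measured in a functional assay on MDA-MB-231 cells (Homo sapiens) for inhibition, with a stated time of 72 h (a lower number here means a stronger inhibitor, a higher number a weaker inhibitor), giving 10200 nM. Compound 1 `Cc1cc(Cl)ccc1NC(=O)Nc1nc(Sc2c[nH]c3ccccc23)cc(N2CCN(Cc3ccccc3)CC2)n1` gives 22100 nM and compound 3 `O=C(Nc1ccccc1)Nc1nc(Sc2c[nH]c3ccccc23)cc(N2CCN(c3ccccn3)CC2)n1` gives 19500 nM. The step of a 2.2-fold lower number from compound 1 to compound 2 (0.34 log units; beyond the scatter) is the only one beyond the scatter; the step of a 1.9-fold higher number from compound 2 to compound 3 (0.28 log units; within the scatter) is not. Compound 4 `COc1ccc(NC(=O)Nc2nc(Sc3c[nH]c4ccccc34)cc(N3CCN(Cc4ccccc4)CC3)n2)cc1` differs from compound 2 by methoxy in place of hydrogen on an aromatic carbon. For the measured compounds named here, only the step from compound 1 to compound 2 bears on this ring, and it shows a modest effect of substitution there, with the substituted ring giving the higher number. A step of similar modest size toward a higher number, or none beyond the scatter, is therefore expected. Compound 4 is expected at 13000 nM, within 5000 nM to 32000 nM. The expected step is a 1.3-fold higher number from compound 2 to compound 4 (0.11 log units; within the scatter).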

Compound 4, half-maximal inhibitory concentration: 8920 nM
Compound 4: middle estimate off by 1.5-fold (0.16 log units), on the high side, within the range that was stated.
By their numbers in this assay, from the lowest: compounds 4, 2, 3 and 1 (each within the scatter of the next, the first and the last beyond it).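

In this assay, for the compounds shown here, methoxy on the urea phenyl, para to a large group, gives a 1.1-fold lower number from compound 2 to compound 4 (0.06 log units; within the scatter) and so does not move the number beyond the scatter, which the earlier compounds could not show for this substituent. 4-Methoxyphenyl in place of 4-chloro-2-methylphenyl gives a 2.5-fold lower number from compound 1 to compound 4 (0.39 log units; beyond the scatter) and so shows that a substituted ring here need not carry the higher number of compound 1. No measurement at hand explains either step.

From the compounds shown here alone, whether the higher number of compound 1 follows from its chloro or its methyl group remains open. Going by these compounds, the outcome with an amine or a carboxylic acid para to the large group also remains open.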